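Alkyl chain growth and lipophilicity in the series

The source may hold more compounds than are shown below. What is called first, only, known or untested is meant among the compounds shown, and "the series" means these compounds.

Measured in a physicochemical assay for lipophilicity, using the shake flask method, at pH 7.4; a lower number here means a more polar compound, a higher number a more lipophilic compound:
Compound 1, `CCC(Oc1ccc(-n2cc(C(F)(F)F)cn2)cc1)c1ccc(C(=O)NCCC(=O)O)cc1`: compound 1 gives 1.9.
Compound 2, `CCCC(Oc1ccc(-n2cc(C#N)cn2)cc1)c1ccc(C(=O)NCCC(=O)O)cc1`: compound 2 gives 1.2.
Compound 3, `CCCC(Oc1ccc(-n2cc(C(F)(F)F)cn2)cc1)c1ccc(C(=O)NCCC(=O)O)cc1`: compound 3 gives 2.4.

Compound 3 holds the highest of the three numbers in this assay. Its nearest neighbour is compound 1: a number 0.50 log units higher from compound 1 to compound 3 (beyond the scatter). The widest gap is to compound 2: a number 1.20 log units higher from compound 2 to compound 3 (beyond the scatter).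

Compound 4, `CC(C)CC(Oc1ccc(-n2cc(C(F)(F)F)cn2)cc1)c1ccc(C(=O)NCCC(=O)O)cc1`, is not yet measured. The change from compound 3 is methyl in place of hydrogen on a saturated chain carbon bound to two saturated chain carbons. Within the data shown here, only one measured step bears on this directly, namely a number 0.50 log units higher from compound 1 to compound 3 (beyond the scatter), which likewise added a methyl to the saturated chain and moved the number up by a modest amount beyond the scatter. The step of a number 1.20 log units higher from compound 2 to compound 3 (beyond the scatter) concerns a different part of the molecule and is set aside. Nothing in the data suggests that a second chain methyl should behave differently from the first, so a step of similar size, upward and beyond the scatter, is expected: a number 0.50 log units higher from compound 3 to compound 4 (beyond the scatter). Compound 4 is therefore estimated at 2.9, with a range from 2.5 to 3.3.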

Compound 4, distribution coefficient: 3.2
For compound 4 the middle estimate is 0.30 log units below the measured one; low and high end bracket the measured number.
By their numbers in this assay, from the lowest: compound 2; then compound 1; then compound 3; then compound 4.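

In this assay the saturated chain carbon takes a further methyl without the rise levelling off, as a number 0.80 log units higher from compound 3 to compound 4 (beyond the scatter) runs in the same direction as the earlier a number 0.50 log units higher from compound 1 to compound 3 (beyond the scatter) and also lies beyond the scatter. Taken whole, the replacement of ethyl by isobutyl on the shared core gives a number 1.30 log units higher from compound 1 to compound 4 (beyond the scatter) and is printed as large, the same size class as a number 1.20 log units higher from compound 2 to compound 3 (beyond the scatter) from the exchange of nitrile for trifluoromethyl, so among compound 1, compound 3 and compound 4 the number goes up with each added methyl and none of the three goes against this. No supporting data bear on why these steps have the size they do.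

The compounds shown leave open whether a straight butyl chain would land near compound 4, so the branch in isobutyl cannot be told apart from the added carbon itself. They also leave open whether a longer chain, or a chain carrying a hydroxyl group or an amine, would continue the same upward run, and whether the exchange of trifluoromethyl for nitrile would give a similar step on the isobutyl compound.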